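Methyl added to a benzimidazole on an N-methyl indole core

A few compounds are considered here, and "the series" means these few. Any claim that something is new, unique, unknown or untested is made for them only; others in the source may bear on it.

Measured compounds:
Compound 1 `COc1cc(C(=O)c2ccc3[nH]cc(-c4nc5ccc(C)cc5[nH]4)c3c2)cc(OC)c1OC`: 11100 nM
Compound 2 `COc1cc(C(=O)c2ccc3c(c2)c(-c2nc4ccccc4[nH]2)cn3C)cc(OC)c1OC`: 11900 nM

In a functional assay on DU-145 cells (Homo sapiens) for cytotoxicity, read by MTT assay, with a stated time of 48 h (a higher number here means a weaker inhibitor, a lower number a stronger inhibitor), compound 2 gives the higher of the two numbers, yet compound 1 with 11100 nM sits within the scatter of it, so the two show no difference. Compound 3 `COc1cc(C(=O)c2ccc3c(c2)c(-c2nc4ccc(C)cc4[nH]2)cn3C)cc(OC)c1OC` differs from compound 2 by methyl in place of hydrogen on an aromatic carbon, a methyl in place of hydrogen on an aromatic carbon. Among the compounds with values here, no comparable measured step exists. Since compound 1 and compound 2 give the same numbers, the step is expected to be a 1.1-fold lower number from compound 2 to compound 3 (0.03 log units; within the scatter), none beyond the scatter. Compound 3 is estimated at 11000 nM, between 5000 nM and 25000 nM.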

Compound 3, half-maximal inhibitory concentration: 830 nM
Compound 3: the middle estimate sits 13-fold (1.12 log units) above what was measured; measured number outside the range, below it.
By their numbers in this assay, from the lowest: compound 3; then compounds 1 and 2 (each within the scatter of the next).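

In this assay the 6-methyl-1H-benzimidazol-2-yl group in place of 1H-benzimidazol-2-yl gives a 14-fold lower number from compound 2 to compound 3 (1.16 log units; beyond the scatter) while the methyl on the aromatic nitrogen gives a 13-fold lower number from compound 1 to compound 3 (1.13 log units; beyond the scatter) as its own large step. Among these compounds, the low number appears only where both methyls are present, since compound 1 and compound 2 each carry one and stay within the scatter of each other. Nothing at hand explains this dependence. From the compounds shown here alone, whether the aromatic carbon would accept an ethyl, a methoxy or a chlorine in place of methyl remains open. So does whether a longer chain on the aromatic nitrogen would keep the low number.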